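From an Aryl-Bearing Benzyl Arm to a Plain Pentyl Chain

The source may report more compounds than this note shows. Statements on the series, on what has been measured and on what is new or still open speak of the compounds shown alone.

Of the compounds shown here, two have been measured in an assay for binding affinity to Alpha-1B adrenergic receptor (Homo sapiens); on this read-out lower numbers stand for stronger inhibition and higher numbers for weaker inhibition. Compound 1 `CN1CCC[C@@H]1Cn1nc(Cc2ccc(F)c(F)c2)c2ccccc2c1=O` gives 316 nM, the higher of the two numbers. Going by the values given here, compound 2 `CN1CCC(Cn2nc(Cc3ccc(Cl)cc3)c3ccccc3c2=O)C1` gives 79.4 nM in this assay, a lower number than compound 1 by a margin beyond the usual scatter; compound 2 differs from compound 1 in more than one place, so no single step can be drawn between them.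

Compound 3 `CCCCCc1nn(C[C@H]2CCCN2C)c(=O)c2ccccc12` has not yet been measured. Relative to compound 1 the change is butyl in place of 3,4-difluorophenyl on a saturated chain carbon bound to an aromatic carbon. The aromatic ring that carried the two fluorine atoms is gone and a short saturated chain stands in its place, while the shared core and the methylpyrrolidinyl-methyl arm are unchanged.

Among the compounds with values here, no measured pair shows this kind of change, so there is nothing to anchor its size. The author expects a step of a 2.5-fold higher number from compound 1 to compound 3 (0.40 log units; beyond the scatter) toward a weaker number, moderate but beyond the scatter. Compound 3 is estimated at 800 nM, with a range from 200 nM to 3000 nM.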

Compound 3, inhibition constant: 1000 nM
For compound 3 the middle estimate is 1.3-fold (0.10 log units) below the measured one; low and high end bracket the measured number.
By their numbers in this assay, from the lowest: compound 2; then compound 1; then compound 3.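

In this assay, going by these compounds alone, putting butyl in place of 3,4-difluorophenyl on a saturated chain carbon bound to an aromatic carbon gives a 3.2-fold higher number from compound 1 to compound 3 (0.50 log units; beyond the scatter) and so supplies the first step in this set that can be read at a single place. It shows that this position responds to the change, but only modestly: the aromatic ring and both fluorine atoms leave together, and compound 3 still gives a measurable 1000 nM on the same read-out. Nothing measured here explains the size or the direction of this step.

The step removes the ring and the fluorine atoms at once, so the compounds shown do not separate the two; a plain phenyl or a cyclohexyl ring in the same place would tell the loss of the fluorine atoms from the loss of the aromatic ring. As far as these compounds go, how far the number depends on the length of the saturated chain also stays open, and a longer chain such as heptyl, or a shorter one such as ethyl, would address that.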